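Aryl exchange from compound 3 to compound 4

This account rests on a few compounds, and the source may have more. Where it says the series, first, only, none or still open, it means among the compounds named here.

- compound 1 `C=C[C@]1(C)C[C@@H](OC(=O)CNC(=O)Nc2cccc(Br)c2)[C@]2(C)[C@H](C)CC[C@]3(CCC(=O)[C@H]32)[C@@H](C)[C@@H]1O` gives > 10000 nM (a limit)
- compound 2 `C=C[C@]1(C)C[C@@H](OC(=O)CNC(=O)NC(=O)c2ccc(Br)cc2)[C@]2(C)[C@H](C)CC[C@]3(CCC(=O)[C@H]32)[C@@H](C)[C@@H]1O` gives > 10000 nM (a limit)
- compound 3 `C=C[C@]1(C)C[C@@H](OC(=O)CNC(=O)Nc2ccc(Cl)cc2)[C@]2(C)[C@H](C)CC[C@]3(CCC(=O)[C@H]32)[C@@H](C)[C@@H]1O` gives > 10000 nM (a limit)

In a functional assay on HT-29 cells (Homo sapiens) for inhibition, read by MTT assay, with a stated time of 72 h (a higher number here means a weaker inhibitor, a lower number a stronger inhibitor), compound 3 gives only a limit (> 10000 nM) and not a number. Going by the values given here, the series so far shows the limit of > 10000 nM in this assay, at which 3 of the 3 values shown sit, and no number yet.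

The change to compound 4 `C=C[C@]1(C)C[C@@H](OC(=O)CNC(=O)Nc2ccc(F)cc2F)[C@]2(C)[C@H](C)CC[C@]3(CCC(=O)[C@H]32)[C@@H](C)[C@@H]1O` puts 2,4-difluorophenyl in place of 4-chlorophenyl on an amide-type nitrogen.

Three measured steps exchange the group on that same nitrogen (a step that the two limits leave unreadable from compound 1 to compound 3; a step that the two limits leave unreadable from compound 2 to compound 3; a step that the two limits leave unreadable from compound 1 to compound 2). None of them has a readable size, and none gives a direction. Among compounds 1, 2 and 3, no exchange on this nitrogen has yet produced a number in this assay and no compound goes against this. No step beyond the scatter is therefore expected, and no direction can be assigned. A further limit is the likeliest report for the new compound.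

Should a number be reported, the estimate for compound 4 is 15000 nM with an expected range from 6000 nM to 40000 nM in this case. The expected step reads a step that the limit leaves unreadable from compound 3 to compound 4 on that estimate.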

Compound 4, half-maximal inhibitory concentration: > 10000 nM
Compound 4 gave a limit, no number; the forecaster's own chance of this, stated with the estimate: 80%; the middle value is on the limit's open side.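

In this assay compound 4 gives > 10000 nM, a limit and not a number. No step from compound 1, compound 2 or compound 3 to compound 4 can be read, and the series stands at: the limit of > 10000 nM in this assay, at which 4 of the 4 values shown sit.

The compounds shown leave open the size and direction of any exchange on the amide-type nitrogen in this assay.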